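Moving from a benzyl to a dichlorophenyl amide

The compounds below may be only part of what the source reports. "The series", "measured", "known", "first", "only" and "open" are said of these compounds alone.

Compound 2 `COc1ccc2nc(C)cc(OCC(=O)NCc3cc(C)cc(C)c3)c2c1` stands highest of the two numbers in a physicochemical assay for solubility, in phosphate buffer, measured as kinetic solubility, with a stated time of 1 h, at pH 7.4 (a higher number here means a more soluble compound, a lower number a less soluble compound), where compound 2 gives 92000 nM. Its nearest neighbour is compound 1 `COc1ccc2nc(C)cc(OC(C)C(=O)Nc3cc(C)cc(C)c3)c2c1`, for which this assay records 61000 nM, a gap that lies within the scatter, so the two cannot be ordered. Compound 3 `COc1ccc2nc(C)cc(OCC(=O)Nc3ccc(Cl)cc3Cl)c2c1` has not yet been measured in this assay. The change from compound 2 is 2,4-dichlorophenyl in place of 3,5-dimethylbenzyl on an amide-type nitrogen. Within the data shown here, no measured pair shows this change, so the step is expected to be downward and beyond the scatter, as a 3.1-fold lower number from compound 2 to compound 3 (0.49 log units; beyond the scatter). Compound 3 is therefore estimated at 30000 nM, within 10000 nM to 80000 nM.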

Compound 3, solubility: 20500 nM
Beside the measured number, compound 3's estimate is 1.5-fold (0.17 log units) above it, and the stated range covers the measured number.
By their numbers in this assay, from the lowest: compound 3; then compounds 1 and 2 (each within the scatter of the next).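

In this assay the group on the amide-type nitrogen proves to matter: 2,4-dichlorophenyl in place of 3,5-dimethylbenzyl gives a 4.5-fold lower number from compound 2 to compound 3 (0.65 log units; beyond the scatter), a modest change but the only step shown, and it lies beyond the scatter. Nothing shown bears on why the number falls. This one swap changes both the ring's substituents and the benzyl carbon, so the compounds leave these two changes unseparated. As far as these compounds go, a 2,4-dichlorobenzyl group on the same nitrogen would separate them, and how an amine or a carboxylic acid there would read remains open.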